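Piperidine for Cyclohexylmethyl on a Melanocortin Receptor 4 Ligand

A few compounds are considered here, and "the series" means these few. Any claim that something is new, unique, unknown or untested is made for them only; others in the source may bear on it.

Compound 1 `CCN(CC)CCCC(C)/N=C(/N)NC(=O)c1cccc(Cl)c1CCc1cc(Br)ccc1OC`: 0.83 nM
Compound 2 `COc1ccc(Br)cc1CCc1c(F)cccc1C(=O)/N=C(\N)NCCC1CCCCC1`: 2600 nM
Compound 3 `CCN(CC)CCCC(C)/N=C(/N)NC(=O)c1cccc(F)c1CCc1cc(Br)ccc1OC`: 4.3 nM

In an assay for binding affinity to Melanocortin receptor 4 (Homo sapiens) (on this read-out higher numbers stand for weaker inhibition and lower numbers for stronger inhibition), compound 2 gives the highest number of the three, well beyond the scatter from compound 3 and from compound 1, so it is the weakest binder here. Compound 4 `COc1ccc(Br)cc1CCc1c(F)cccc1C(=O)/N=C(\N)NCC1CCNCC1` is derived from compound 2 by one change: piperidin-4-yl in place of cyclohexylmethyl on a saturated chain carbon bound to an amine nitrogen. Among the compounds with values here, the only measured step, a 5.2-fold higher number from compound 1 to compound 3 (0.71 log units; beyond the scatter), concerns a halogen on an aromatic carbon and does not bear on a change in the amine-bearing chain. Within the data shown here, compounds 1 and 3 differ from compound 2 in their amine side chains and both give far lower numbers, though no single-point step links them to compound 2. On that basis a sizeable drop in the number is expected for compound 4, while its exact size remains uncertain. The estimated step is a 17-fold lower number from compound 2 to compound 4 (1.24 log units; beyond the scatter). Compound 4 is therefore expected to give 150 nM in this assay, with a range from 25 nM to 900 nM.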

Compound 4, inhibition constant: 13 nM
For compound 4 the middle estimate is 12-fold (1.06 log units) above the measured one; the measured number lies below the stated range.
By their numbers in this assay, from the lowest: compound 1; then compound 3; then compound 4; then compound 2.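

In this assay, within the data shown here, the step of a 200-fold lower number from compound 2 to compound 4 (2.30 log units; beyond the scatter) is the first single change read in the amine-bearing chain, and it shows that binding responds strongly to the group at this place. Piperidin-4-yl in place of cyclohexylmethyl puts a ring nitrogen where the ring held only carbon, adding one hydrogen-bond donor and one acceptor, and this exchange alone separates a weak binder from a much stronger one. No measurement shown here explains why the step is so large.

The compounds shown do not tell whether a ring nitrogen carrying a methyl group, or an open-chain primary amine such as 2-aminoethyl, would give a similar number. Going by these compounds, it also remains open whether the same exchange would have a step of similar size with chloro in place of fluoro on the aromatic carbon.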